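The source may report more compounds than this note shows. Statements on the series, on what has been measured and on what is new or still open speak of the compounds shown alone.

Measured so far in an assay on isolated protein for inhibition of protein deacetylase HDAC6 (Homo sapiens), read by fluorescence, with a stated time of 15 min; a lower number here means a stronger inhibitor, a higher number a weaker inhibitor: compound 1 `O=C(NO)c1cccc(/C=C/c2ccnc(-c3cc(F)ccc3O)c2)c1` gives 400 nM; compound 2 `O=C(NO)c1ccc(/C=C/c2ccnc(-c3ccccc3O)c2)cc1` gives 47 nM.

Compound 2 holds the lower of the two numbers in this assay; compound 1 sits well beyond the scatter above it, and the two structures differ in more than one place, so their gap is not read as a single step.

Compound 3 `O=C(NO)c1ccc(/C=C/c2ccnc(-c3cccc(CO)c3)c2)cc1` carries the change 3-(hydroxymethyl)phenyl in place of 2-hydroxyphenyl on an aromatic carbon on the core shared with compound 2. Within the data shown here, no measured step of this kind exists. A modest weakening is expected, near the edge of the scatter, a 2.3-fold higher number from compound 2 to compound 3 (0.37 log units; beyond the scatter). For compound 3 the estimate in this assay is 110 nM, ranging from 35 nM to 400 nM.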

Compound 3, half-maximal inhibitory concentration: 34 nM
Beside the measured number, compound 3's estimate is 3.2-fold (0.51 log units) above it, and the stated range ends above it.
By their numbers in this assay, from the lowest: compounds 3 and 2 (each within the scatter of the next); then compound 1.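

In this assay, 3-(hydroxymethyl)phenyl in place of 2-hydroxyphenyl on an aromatic carbon next to the ring nitrogen gives a 1.4-fold lower number from compound 2 to compound 3 (0.14 log units; within the scatter). Among these compounds, this is the first single-place step, and it shows that this position can carry either of these two substituted phenyl groups with no difference readable beyond the scatter. No measurement at hand bears on why the two groups read alike.

Still open, from the compounds shown here alone, is whether the same holds for a phenyl ring carrying an aminomethyl group or a carboxylic acid at this position. Also open, going by these compounds, is whether the hydroxymethyl group gives the same reading as 2-(hydroxymethyl)phenyl or 4-(hydroxymethyl)phenyl.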